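Swapping furan-3-yl for 4-fluorophenyl on a flat series

The source may hold more compounds than are shown below. What is called first, only, known or untested is meant among the compounds shown, and "the series" means these compounds.

- compound 1 `O=C1NC(=O)c2ccc(I)cc2/C1=C/Nc1ccc(CN2CCCCC2)cc1` 1000 nM
- compound 2 `CN1CCN(c2ccc(N/C=C3\C(=O)NC(=O)c4ccc(-c5ccoc5)cc43)cc2)CC1` 1100 nM
- compound 3 `O=C1NC(=O)c2ccc(-c3ccoc3)cc2/C1=C/Nc1ccc(CN2CCCCC2)cc1` 1100 nM

Within the data shown here, in a functional assay on MCF7 cells (Homo sapiens) for antiproliferative activity, read by sulforhodamine B assay (a higher number here means a weaker inhibitor, a lower number a stronger inhibitor), compound 3 gives 1100 nM and sits level with compound 2, while compound 1 lies within the scatter of both, so no compound stands apart. Compound 4 `O=C1NC(=O)c2ccc(-c3ccc(F)cc3)cc2/C1=C/Nc1ccc(CN2CCCCC2)cc1` has not been measured yet. It differs from compound 3 in one place 4-fluorophenyl in place of furan-3-yl on an aromatic carbon and carries 4-fluorophenyl in place of furan-3-yl on an aromatic carbon.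

Among the measured compounds shown here, two measured steps bear on this. Furan-3-yl in place of iodo on that carbon gave a 1.1-fold higher number from compound 1 to compound 3 (0.04 log units; within the scatter) and (piperidin-1-yl)methyl in place of 4-methylpiperazin-1-yl gave no change at the digits printed from compound 2 to compound 3 (within the scatter) at the other end of the molecule. Neither step left the scatter, but neither tested 4-fluorophenyl, so the evidence is thin. The estimated outcome is no change at the digits printed from compound 3 to compound 4 (within the scatter) in this assay and no step beyond the scatter is expected in either direction. Compound 4 is estimated at 1100 nM and expected to fall between 500 nM and 2400 nM.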

Compound 4, half-maximal inhibitory concentration: 550 nM
Compound 4: middle estimate off by 2.0-fold (0.30 log units), on the high side; measured number inside the range.
By their numbers in this assay, from the lowest: compounds 4, 1, 2 and 3 (each within the scatter of the next).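

In this assay, 4-fluorophenyl in place of furan-3-yl gives a 2.0-fold lower number from compound 3 to compound 4 (0.30 log units; within the scatter), showing that this aromatic carbon can carry a six-membered aromatic ring of carbon only, with 7 heavy atoms and no hydrogen-bond acceptor, as well as a five-membered aromatic ring with 5 heavy atoms and 1 hydrogen-bond acceptor. With 4-fluorophenyl in place of iodo the result is a 1.8-fold lower number from compound 1 to compound 4 (0.26 log units; within the scatter), so with (piperidin-1-yl)methyl held constant, all three groups compared at this carbon stay within the scatter of one another. No supporting measurement is available to explain this outcome.

The compounds shown leave open whether a carboxylic acid or a primary amine on this carbon would move the number beyond the scatter. They also leave open how 4-fluorophenyl behaves alongside 4-methylpiperazin-1-yl at the other end of the molecule.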